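The source may hold more compounds than are shown below. What is called first, only, known or untested is meant among the compounds shown, and "the series" means these compounds.

Working notes on the series. Compound 1 `CC1(c2ccccc2)CC(=O)N(CC(=O)N2CCN(c3ccc(Cl)cc3)CC2)C1=O` carries a 4-chlorophenyl on the amine nitrogen in the ring; in a functional assay on the whole organism (strain CD-1) with Mus musculus as the target, with a stated time of 0.5 h (a lower number here means that less compound is needed, a higher number that more compound is needed for the effect), compound 1 gives 300 mg/kg. Compound 2 `COc1ccccc1N1CCN(C(=O)CN2C(=O)CC(C)(c3ccccc3)C2=O)CC1` differs in the aryl group on that nitrogen, and in this assay compound 2 is recorded as "not active" (no number reported), with no number given. Compound 3 `CC1(c2ccccc2)CC(=O)N(CC(=O)N2CCN(c3cccc(Cl)c3Cl)CC2)C1=O` carries a 2,3-dichlorophenyl in the same place, and in this assay compound 3 gives 300 mg/kg. Compound 3 thus stands level with compound 1 at the digits shown; the step of no change at the digits printed from compound 1 to compound 3 (within the scatter) lies within the scatter. The one further entry, compound 2, gives no number to compare.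

Compound 4 `CC1(c2ccccc2)CC(=O)N(CC(=O)N2CCN(c3ccc(Cl)c(Cl)c3)CC2)C1=O` is the next member. The change from compound 3 is 3,4-dichlorophenyl in place of 2,3-dichlorophenyl on an amine nitrogen in a ring. Among the measured compounds shown here, the only step that bears on it is the one from compound 1 to compound 3, which moved a chlorine pattern on the same phenyl and produced no change beyond the scatter. For the measured compounds named here, nothing among the measured compounds indicates that shifting the two chlorines again should move the dose. The expectation for compound 4 is therefore a step of no change at the digits printed from compound 3 to compound 4 (within the scatter), that is, none beyond the scatter. Compound 4 is estimated at 300 mg/kg in this assay, with a range from 150 mg/kg to 600 mg/kg; the inactive compound 2 leaves some chance that no number is obtained.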

Compound 4, minimum effective dose: "not active" (no number reported)
No number was reported for compound 4, so the estimate cannot be set against anything.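

Among the compounds shown here, compound 4 is recorded without a number in this assay, so no step from compound 3 to compound 4 can be read. No measured property bears on this result. The compounds shown leave open how far the 3,4-dichlorophenyl group of compound 4 separates it from compound 3 in this assay.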